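A few compounds are considered here, and "the series" means these few. Any claim that something is new, unique, unknown or untested is made for them only; others in the source may bear on it.

The three measured compounds:

compound 1, `CSc1nnc(-c2ccccc2F)n1C`, gives 8.8 mg/kg
compound 2, `Cn1c(-c2ccccc2F)nnc1[S+](C)[O-]`, gives 20 mg/kg
compound 3, `CC[S+]([O-])c1nnc(-c2ccccc2F)n1C`, gives 32.7 mg/kg

These values come from a functional assay on the whole organism for antagonist activity, with Mus musculus as the target; a higher number here means that more compound is needed for the effect, a lower number that less compound is needed. Compound 1 has the lowest number of the three. The step of a 2.3-fold higher number from compound 1 to compound 2 (0.36 log units; beyond the scatter) and the step of a 3.7-fold higher number from compound 1 to compound 3 (0.57 log units; beyond the scatter) both go beyond the scatter, so compound 1 stands apart from the other two. Compound 1 and compound 2 differ on the shared core by a group of 2 heavy atoms (1 carbon, 1 sulfur; no ring) in place of a group of 3 heavy atoms (1 carbon, 1 oxygen, 1 sulfur; no ring), on an aromatic carbon. Compound 2 and compound 3 differ only by methyl in place of hydrogen on a saturated chain carbon bound to a sulfur, and the step of a 1.6-fold higher number from compound 2 to compound 3 (0.21 log units; within the scatter) stays within the scatter, so the two cannot be placed in an order.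

Compound 4, `CCn1c(SC)nnc1-c1ccccc1F`, has not yet been measured. It differs from compound 1 by methyl in place of hydrogen on a saturated chain carbon bound to an aromatic nitrogen. Going by the values given here, this is the same kind of change as the one from compound 2 to compound 3, not the same change: there the methyl enters on a saturated chain carbon bound to a sulfur, here on a saturated chain carbon bound to an aromatic nitrogen. Both sit on the same core, and compound 1 and compound 2 differ at another position. The expectation rests on one pair only, so it is rough. For compound 4 a step of a 1.4-fold higher number from compound 1 to compound 4 (0.13 log units; within the scatter) is expected, beside the earlier step of a 1.6-fold higher number from compound 2 to compound 3 (0.21 log units; within the scatter), because the step of a 1.6-fold higher number from compound 2 to compound 3 (0.21 log units; within the scatter) was within the scatter. Compound 4 is therefore estimated at 12 mg/kg, with a likely range from 6 mg/kg to 25 mg/kg.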

Compound 4, dose for half-maximal effect: 75 mg/kg
For compound 4 the middle estimate is 6.3-fold (0.80 log units) below the measured one, and the stated range ends below it.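

In this assay, methyl in place of hydrogen on a saturated chain carbon bound to an aromatic nitrogen, which turns the methyl group there into ethyl, gives an 8.5-fold higher number from compound 1 to compound 4 (0.93 log units; beyond the scatter), so much more compound is needed for the effect. A small addition that made no readable difference in one pair therefore made a clear difference in the other, which shows that the size of this step cannot simply be carried from one core to another in this series: the same change on two cores in this assay, a 1.6-fold higher number (0.21 log units; within the scatter) from compound 2 to compound 3 and an 8.5-fold higher number (0.93 log units; beyond the scatter) from compound 1 to compound 4, 5.2-fold (0.72 log units) apart, beyond the scatter of two such steps. Going by these compounds alone, this does not show why the two steps differ: the added methyl stands in a different place in each pair and the groups on the shared core differ too, and with only one pair of each kind these two differences cannot be separated.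

The compounds shown leave open whether ethyl on the aromatic nitrogen would have the same large effect alongside the sulfur-bearing group of compound 2. They also leave open how the number would respond to a longer chain such as propyl, or to a small ring such as cyclopropyl, at that same place.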